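Second benzyl ether on the biphenyl bis-allyl core

The source may hold more compounds than are shown below. What is called first, only, known or untested is meant among the compounds shown, and "the series" means these compounds.

Measured compounds:
compound 1, `C=CCc1ccc(OCc2ccccc2)c(-c2ccc(O)c(CC=C)c2)c1`, 24000 nM
compound 2, `C=CCc1ccc(O)c(-c2ccc(OCc3c(Cl)cccc3Cl)c(CC=C)c2)c1`, 16400 nM
compound 3, `C=CCc1ccc(OCc2c(Cl)cccc2Cl)c(-c2ccc(OCc3c(Cl)cccc3Cl)c(CC=C)c2)c1`, > 50000 nM

Of the compounds shown here, three sharing the same core have been measured in a functional assay on CNE2Z cells (Homo sapiens) for inhibition, read by MTT assay, with a stated time of 72 h; a lower number here means a stronger inhibitor, a higher number a weaker inhibitor. Compound 1 gives 24000 nM, the highest of the two plain numbers, and compound 2 gives 16400 nM, which lies within the scatter of compound 1. Compound 3 gives > 50000 nM, a limit of the assay rather than a number (the limit of > 50000 nM in this assay, at which 1 of the 3 values shown sits).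

The unmeasured compound 4, `C=CCc1ccc(OCc2ccccc2)c(-c2ccc(OCc3ccccc3)c(CC=C)c2)c1`, differs from compound 1 in one place: benzyl in place of hydrogen on an oxygen on an aromatic ring. Among the compounds with values here, the step that bears on this is the one from compound 2 to compound 3, where the second benzylic ether was added in the same way and the number rose: an at least 3.0-fold higher number from compound 2 to compound 3 (0.48 log units; beyond the scatter). Since the change from compound 1 to compound 4 is the same kind of step, a rise in this assay of similar size is expected, with a real chance that only a limit is reported. For compound 4 the estimate is 60000 nM, in the range 25000 nM to 150000 nM, which is an expected step of a 2.5-fold higher number from compound 1 to compound 4 (0.40 log units; beyond the scatter).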

Compound 4, half-maximal inhibitory concentration: > 50000 nM
Compound 4 was reported as a limit; the forecaster's own chance of this, stated with the estimate: 55%; the middle value lies beyond the limit too.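

In this assay, the step with plain benzyl on the free oxygen of compound 1 is an at least 2.0-fold higher number from compound 1 to compound 4 (0.31 log units; beyond the scatter), and this size is only a lower bound. The earlier step had shown such a rise only with 2,6-dichlorobenzyl, so the rise now also appears with a benzyl group that carries no chlorine. Compound 4 is reported only as a limit of the assay, and it is not alone in this: the limit of > 50000 nM in this assay, at which 2 of the 4 values shown sit.

Going by these compounds, how far the number rises beyond that bound stays open for both steps, as does any order between compound 3 and compound 4. Also open, on these data alone, is whether a methyl group on this oxygen, or a benzyl group bearing an amine or a carboxylic acid, would give the same rise.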